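A Second Fluorine Enters the Aryl Ring

A few compounds are considered here, and "the series" means these few. Any claim that something is new, unique, unknown or untested is made for them only; others in the source may bear on it.

The shared core is an ester-bearing bicyclic ring system carrying a trifluoromethyl group and an isoxazole-linked ether, varied only at the outer phenyl ring. Compound 1 `CCOC(=O)C1=Cc2ccccc2OC1(OCc1cc(-c2ccc(OC)cc2)no1)C(F)(F)F` carries a methoxy group on that ring. In a functional assay on HeLa cells (Homo sapiens) for inhibition, read by MTT assay, with a stated time of 24 h (on this read-out lower numbers stand for stronger inhibition and higher numbers for weaker inhibition), compound 1 gives only a limit of > 150000 nM, not a measured number. Compound 2 `CCOC(=O)C1=Cc2ccccc2OC1(OCc1cc(-c2ccc(F)cc2)no1)C(F)(F)F` carries a fluoro group instead, and in this assay compound 2 gives 42300 nM. That change is an at least 3.5-fold lower number from compound 1 to compound 2 (0.54 log units; beyond the scatter), so compound 2 holds the only measured number shown, while the other value is a limit (the limit of > 150000 nM in this assay, at which 1 of the 2 values shown sits).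

Compound 3 `CCOC(=O)C1=Cc2ccccc2OC1(OCc1cc(-c2ccc(F)cc2F)no1)C(F)(F)F` adds a further change: fluoro in place of hydrogen on an aromatic carbon. Within the data shown here, the one measured step swaps methoxy for fluoro on the same ring, which is not the same change as adding a second fluoro, so it offers only indirect guidance. A small step, within or just beyond the scatter, is expected, most likely a modestly lower number, giving an expected step of a 1.4-fold lower number from compound 2 to compound 3 (0.15 log units; within the scatter). Compound 3 is therefore estimated at 30000 nM, within a range from 10000 nM to 100000 nM.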

Compound 3, half-maximal inhibitory concentration: > 150000 nM
Compound 3: no number, only a limit; the forecaster's own chance of this, stated with the estimate: 15%; middle value at least 5.0-fold (0.69 log units) from the limit.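

The change from 4-fluorophenyl to 2,4-difluorophenyl gives an at least 3.5-fold higher number from compound 2 to compound 3 (0.54 log units; beyond the scatter) in this assay. A single added fluoro, ortho to a large group, is therefore enough to weaken inhibition clearly, even though this small atom replaces only a hydrogen. The earlier step showed only that compound 2, with fluoro in place of methoxy, gives a lower number than compound 1, whereas this result shows that adding more fluoro to the ring does not extend that gain, and compound 1 and compound 3 each give a limit rather than a number: the limit of > 150000 nM in this assay, at which 2 of the 3 values shown sit.

Among these compounds, the step between compound 1 and compound 3 cannot be read, as two limits cannot be compared, and compound 2 remains the only compound here with a measured number to compare against. From the compounds shown here alone, it also remains open whether the weaker inhibition is specific to fluoro or would follow from any group at this place, such as a chlorine, a methyl or an amine, and whether a fluoro elsewhere on the ring would behave the same way.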